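Aryl thioether enones against a prostate carcinoma line

The source may report more compounds than this note shows. Statements on the series, on what has been measured and on what is new or still open speak of the compounds shown alone.

Of the compounds shown here, two have numbers so far. Compound 1 `O=C(/C(=C\c1cc(Br)c(O)c(Br)c1)SCc1ccc(Br)cc1)c1ccc(Br)cc1` gives 1000 nM in a functional assay on DU-145 cells (Homo sapiens) for inhibition, read by trypan blue exclusion, with a stated time of 96 h; a higher number here means a weaker inhibitor of growth, a lower number a stronger inhibitor of growth. Compound 2 `Cc1ccc(S/C(=C/c2ccc(O)c([N+](=O)[O-])c2)C(=O)c2ccc(Cl)cc2)cc1` gives 10000 nM in this assay, the highest of the two numbers; the two compounds differ in several places at once, so the gap between them cannot be traced to any one change, and all that can be said is that compound 2 sits above compound 1, beyond the scatter.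

Compound 3 `O=C(/C(=C\c1ccc(O)c([N+](=O)[O-])c1)Sc1ccccc1Br)c1ccc(Cl)cc1` keeps the core of compound 2 and changes only the ring on the sulfur: 2-bromophenyl in place of 4-methylphenyl on a sulfur. Among the compounds with values here, no measured pair isolates this kind of exchange, so there is no step from which to read its size. The expectation is therefore anchored on compound 2 itself, with a wide range and no firm direction; a step of a 1.7-fold lower number from compound 2 to compound 3 (0.22 log units; within the scatter) within or just beyond the scatter is expected. Compound 3 is estimated at 6000 nM in this assay, in the range 2000 nM to 20000 nM, pending the measurement.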

Compound 3, concentration for 50% growth inhibition: 25000 nM
Estimate against measurement, compound 3: 4.2-fold (0.62 log units) below, and the stated range ends below it.
By their numbers in this assay, from the lowest: compound 1; then compound 2; then compound 3.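

Within the data shown here, the exchange of 4-methylphenyl for 2-bromophenyl on a sulfur is the first change that can be read on its own, and in this assay it gives a 2.5-fold higher number from compound 2 to compound 3 (0.40 log units; beyond the scatter), a modest step beyond the scatter towards weaker inhibition of growth. The ring on the sulfur therefore affects the read-out with this core, even though both groups hold the same number of heavy atoms and a single six-membered aromatic ring of carbon only, and of these two groups the 4-methylphenyl gives the lower number. No measured property accompanies this step, so nothing available assigns it to a particular feature of either group.

With one exchange, the bromine and its place on the ring change together, and the step cannot be split between them; a 2-methylphenyl or a 4-bromophenyl group on the sulfur would separate the two. Also open, as far as these compounds go, is how far the ring on the sulfur tolerates a different kind of group, such as an amine or a carboxylic acid on that ring, or a pyridine in its place.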